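Swapping Chloro for Trifluoromethyl on the Benzyl Ring

This account rests on a few compounds, and the source may have more. Where it says the series, first, only, none or still open, it means among the compounds named here.

Measured compounds:
Compound 1, `CCCn1c(=O)c2nc(-c3cnn(Cc4cc(Cl)ccc4Cl)c3)[nH]c2n(CCC)c1=O`: 29 nM
Compound 2, `CC(C)Cn1c(=O)c2nc(-c3cnn(Cc4cccc(C(F)(F)F)c4)c3)[nH]c2n(CC(C)C)c1=O`: 300 nM

Both were tested in an in vitro assay on HEK293 cells for displacement of a labelled ligand from adenosine receptor A2b (Homo sapiens); a lower number here means a stronger inhibitor, a higher number a weaker inhibitor. Compound 1 gives 29 nM and holds the lower of the two numbers, compound 2 at 300 nM sits higher, beyond the scatter. Going by the values given here, compound 2 also differs from compound 1 in more than one place, so no single step connects them.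

Compound 3, `CCCn1c(=O)c2nc(-c3cnn(Cc4cc(C(F)(F)F)ccc4Cl)c3)[nH]c2n(CCC)c1=O`, changes compound 1 in one spot: trifluoromethyl in place of chloro on an aromatic carbon. Nothing measured here shows this swap alone, so only a small step is expected, if any beyond the scatter: a 1.6-fold higher number from compound 1 to compound 3 (0.19 log units; within the scatter). Compound 3 is estimated at 45 nM, within 15 nM to 140 nM.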

Compound 3, inhibition constant: 22 nM
Compound 3: middle estimate off by 2.0-fold (0.31 log units), on the high side; measured number inside the range.
By their numbers in this assay, from the lowest: compounds 3 and 1 (each within the scatter of the next); then compound 2.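

In this assay, replacing chloro with trifluoromethyl on the aromatic carbon para to the chloro group gives a 1.3-fold lower number from compound 1 to compound 3 (0.12 log units; within the scatter), turning 2,5-dichlorophenyl into 2-chloro-5-(trifluoromethyl)phenyl. This position therefore holds four heavy atoms in place of one with no change beyond the scatter. No measurement here explains why the two groups read alike.

As far as these compounds go, whether a nitrile, a methoxy group or an amine at this position would read the same stays open. Compound 2 differs from compound 1 in several places, so its higher number cannot be traced to any single change.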